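Fluoro Substitution on the Aryl Ether of Compound 1

The source may hold more compounds than are shown below. What is called first, only, known or untested is meant among the compounds shown, and "the series" means these compounds.

Compound 1 `Cc1ccc(Nc2nc(N)nc(COc3cccc(N4CCCC4=O)c3)n2)cc1Cl`: 820 nM
Compound 2 `Cc1ccc(Nc2nc(N)nc(COc3ccc(Cl)c(N4CCCC4=O)c3)n2)cc1Cl`: 2450 nM
Compound 3 `Cc1ccc(Nc2nc(N)nc(COc3cc(N4CCCC4=O)cc(S(C)(=O)=O)c3)n2)cc1Cl`: "not determined" (no result reported)

Within the data shown here, in an assay on COS-7 cells for agonist activity at Free fatty acid receptor 1 (Homo sapiens), read by scintillation counting and inositol phosphate accumulation, with a stated time of 90 min (on this read-out higher numbers stand for an effect only at larger amounts of compound and lower numbers for an effect already at smaller amounts), compound 1 gives 820 nM, the lowest of the two numbers recorded; the only measured neighbour, compound 2, gives 2450 nM in this assay. Compound 3 has no value in this assay and adds nothing to the comparison.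

Compound 4 `Cc1ccc(Nc2nc(N)nc(COc3cc(N4CCCC4=O)ccc3F)n2)cc1Cl` differs from compound 1 by fluoro in place of hydrogen on an aromatic carbon. Among the measured compounds shown here, the one step that bears on it is a 3.0-fold higher number from compound 1 to compound 2 (0.48 log units; beyond the scatter), a modest weakening on adding a halogen to the same six-membered aromatic ring of carbon only, though at a different carbon of that ring and with chloro rather than fluoro. With a single halogen entering, the step from compound 1 to compound 4 is expected to be small, in the direction of a higher number or none beyond the scatter, as a 1.5-fold higher number from compound 1 to compound 4 (0.17 log units; within the scatter). Compound 4 is therefore estimated to give 1200 nM in this assay, within a range from 500 nM to 3000 nM.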

Compound 4, half-maximal effective concentration: 33100 nM
Compound 4: the middle estimate sits 28-fold (1.44 log units) below what was measured; measured number outside the range, above it.
By their numbers in this assay, from the lowest: compound 1; then compound 2; then compound 4.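

In this assay, fluoro on an aromatic carbon ortho to a large group and para to a 2-oxopyrrolidin-1-yl group gives a 40-fold higher number from compound 1 to compound 4 (1.61 log units; beyond the scatter), a large step for a single entering heavy atom. The earlier step with chloro at a different carbon of the same ring, a 3.0-fold higher number from compound 1 to compound 2 (0.48 log units; beyond the scatter), was only modest, so this ring does not accept every halogen at every carbon alike, although the two steps differ in both the halogen and the carbon. No measurement shown accounts for the size of the new step.

The compounds shown leave open whether chloro, methyl or methoxy at the carbon carrying fluoro in compound 4 would give a similarly large step. They also leave open whether fluoro at the carbon carrying chloro in compound 2 would give a step as modest as chloro does.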